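A Methyl Branch Repeated on a Second Core

A few compounds are considered here, and "the series" means these few. Any claim that something is new, unique, unknown or untested is made for them only; others in the source may bear on it.

Of the compounds shown here, three have so far been tested in a functional assay on U-251 cells (Homo sapiens) for antiproliferative activity, read by sulforhodamine B assay, with a stated time of 72 h; a higher number here means a weaker inhibitor, a lower number a stronger inhibitor. Compound 1 `CC[C@H](C)C(=O)Oc1ccc(/C=C/COC(C)=O)cc1OC` gives 12900 nM in this assay. Compound 3 `CCCC(=O)Oc1ccc(/C=C/COC(C)=O)cc1OC` gives 45700 nM in this assay, and compound 2 `CCCC(=O)OC/C=C/c1ccc(OC(C)=O)c(OC)c1` gives 33300 nM in this assay. Of these, compound 2 and compound 3 lie within the scatter of each other, while compound 1 stands beyond the scatter below both.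

Compound 1 and compound 3 share a core and differ in one place: methyl in place of hydrogen on a saturated chain carbon bound to a carbonyl carbon and a saturated chain carbon. That single change gave a 3.5-fold lower number from compound 3 to compound 1 (0.55 log units; beyond the scatter), a modest but real gain.

Compound 2 is built from the same atoms as compound 3, joined differently; the difference between the two cores is not broken down here. Compound 4 `CC[C@H](C)C(=O)OC/C=C/c1ccc(OC(C)=O)c(OC)c1` is related to compound 2 exactly as compound 1 is related to compound 3: methyl in place of hydrogen on a saturated chain carbon bound to a carbonyl carbon and a saturated chain carbon. The place of the change is the same word for word in both pairs, so this is the same change carried onto a second core.

With only one earlier case to go on, the step is expected to be about a 3.5-fold lower number from compound 2 to compound 4 (0.54 log units; beyond the scatter). Going by the values given here, this expectation rests on compound 1, because a 3.5-fold lower number from compound 3 to compound 1 (0.55 log units; beyond the scatter) is the only measured instance of this change. Compound 4 is therefore expected to give about 9500 nM, most likely between 4000 nM and 24000 nM.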

Compound 4, half-maximal inhibitory concentration: 28100 nM
Compound 4: the middle estimate sits 3.0-fold (0.47 log units) below what was measured; the measured number lies above the stated range.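

On the second core, methyl in place of hydrogen gave a 1.2-fold lower number from compound 2 to compound 4 (0.07 log units; within the scatter) in this assay, so there the change from propyl to sec-butyl made no difference that can be told apart from the scatter. The change therefore did not carry the same size of step from one core to the other, even though it sits in the same place in both pairs: the same change on two cores in this assay, a 3.5-fold lower number (0.55 log units; beyond the scatter) from compound 3 to compound 1 and a 1.2-fold lower number (0.07 log units; within the scatter) from compound 2 to compound 4, 3.0-fold (0.48 log units) apart, beyond the scatter of two such steps. This does not show why the two cores part ways, and two pairs are too few to set a rule for any further core, so the result says only that in this small series a step measured on one core did not repeat on the other.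

The compounds shown leave open whether a longer chain, or an amine or a carboxylic acid, in place of the sec-butyl group would respond alike on both cores. They also leave open how the mirror-image form of the sec-butyl group would compare on each core.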